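Shifting a chlorine on the dichlorophenyl group

The compounds below may be only part of what the source reports. "The series", "measured", "known", "first", "only" and "open" are said of these compounds alone.

Measured so far in a functional assay on HCT-116 cells (Homo sapiens) for antiproliferative activity, read by MTT assay, with a stated time of 72 h; on this read-out higher numbers stand for weaker inhibition and lower numbers for stronger inhibition
compound 1 `COc1ccc(OCCCON2C(N)=NC(N)=NC23CCOCC3)cc1` with 1500 nM
compound 2 `NC1=NC2(CCOCC2)N(OCCCOc2ccc(Cl)cc2Cl)C(N)=N1` with 880 nM

For the measured compounds named here, compound 2 at 880 nM sits within the scatter of compound 1, the only other compound measured, so the two cannot be ranked. Compound 3 `NC1=NC2(CCOCC2)N(OCCCOc2ccc(Cl)c(Cl)c2)C(N)=N1` has the same atoms as compound 2 joined differently, with 3,4-dichlorophenyl in place of 2,4-dichlorophenyl on an oxygen on a saturated carbon as the change, which puts 3,4-dichlorophenyl in place of 2,4-dichlorophenyl on an oxygen on a saturated carbon. Going by the values given here, one measured step bears on this, at the same place, and a 1.7-fold lower number from compound 1 to compound 2 (0.23 log units; within the scatter) is what it showed. Among the compounds with values here, that swap of 4-methoxyphenyl for 2,4-dichlorophenyl stayed within the scatter, and no measured step shifts only the chlorines. No step beyond the scatter is therefore expected in this assay for compound 3. The estimated change is a 1.1-fold lower number from compound 2 to compound 3 (0.04 log units; within the scatter) and lies within the scatter. Compound 3 is estimated at 800 nM with 300 nM to 2000 nM as its expected range.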

Compound 3, half-maximal inhibitory concentration: 90 nM
Compound 3: middle estimate off by 8.9-fold (0.95 log units), on the high side; measured number below the stated range.
By their numbers in this assay, from the lowest: compound 3; then compounds 2 and 1 (each within the scatter of the next).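

In this assay, the group on the oxygen on a saturated carbon responds to where the chlorines sit, not only to which group is present: with the same atoms joined differently, the change gave a 9.8-fold lower number from compound 2 to compound 3 (0.99 log units; beyond the scatter). Measured against 4-methoxyphenyl, 3,4-dichlorophenyl gave a 17-fold lower number from compound 1 to compound 3 (1.22 log units; beyond the scatter), whereas 2,4-dichlorophenyl had stayed within the scatter of that group. Nothing available here accounts for the difference between the two chlorine arrangements.

The compounds shown leave open whether both chlorines are needed, or whether 3-chlorophenyl or 4-chlorophenyl alone would give a similar number. They also leave open whether 3,4-difluorophenyl or 3,4-dimethylphenyl would match 3,4-dichlorophenyl, and whether the result would hold with a longer chain carrying the same group.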